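Halogen swap on two cores in a guinea-pig functional assay

This account rests on a few compounds, and the source may have more. Where it says the series, first, only, none or still open, it means among the compounds named here.

Measured compounds:
compound 1 `CC1=CS[C@@](O)(c2ccc(Cl)cc2)c2noc(=O)n21` 800 nM
compound 2 `CC1=CS[C@@](O)(c2ccc(Br)cc2)c2noc(=O)n21` 320 nM
compound 3 `CCCCOC1(c2ccc(Cl)cc2)SC=C(C)n2c1noc2=O` 1850 nM

In a functional assay (Cavia porcellus) with Rattus norvegicus as the target (on this read-out higher numbers stand for an effect only at larger amounts of compound and lower numbers for an effect already at smaller amounts), compound 1 gives 800 nM, and compound 2 gives 320 nM. The change between them, (bromo in place of chloro on an aromatic carbon), yields a 2.5-fold lower number from compound 1 to compound 2 (0.40 log units; beyond the scatter). Compound 3 carries a different core; how it differs from the core of compound 1 is not broken down here. In this assay compound 3 gives 1850 nM, the highest of the three numbers, beyond the scatter from both compound 1 and compound 2.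

Compound 4 `CCCCOC1(c2ccc(Br)cc2)SC=C(C)n2c1noc2=O` has not been measured. It differs from compound 3 by bromo in place of chloro on an aromatic carbon, the same change that separates compound 1 from compound 2. The account expects for compound 4 a step of a 2.5-fold lower number from compound 3 to compound 4 (0.39 log units; beyond the scatter) in this assay, resting on the step of a 2.5-fold lower number from compound 1 to compound 2 (0.40 log units; beyond the scatter), with the untested core leaving room for a wider outcome. Compound 4 is thus estimated at 750 nM, within 350 nM and 1600 nM.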

Compound 4, half-maximal effective concentration: 1020 nM
For compound 4 the middle estimate is 1.4-fold (0.13 log units) below the measured one, within the range that was stated.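

In this assay, bromo in place of chloro on the core of compound 3 gives a 1.8-fold lower number from compound 3 to compound 4 (0.26 log units; within the scatter), so on this core the step cannot be told apart from repeat measurement. Set beside the earlier step, it does not differ from it: the same change on two cores in this assay, a 2.5-fold lower number (0.40 log units; beyond the scatter) from compound 1 to compound 2 and a 1.8-fold lower number (0.26 log units; within the scatter) from compound 3 to compound 4, 1.4-fold (0.14 log units) apart, within the scatter of two such steps. The two pairs are thus compatible with one step carried across both cores, but they do not show that the change has a real effect on the core of compound 3, or that the step would hold on any further core.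

The compounds shown leave open how fluoro, iodo or a nitrile would read in place of the halogen on the aromatic ring. They also leave open whether the step would persist on a core bearing an amine or a longer chain.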